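Replacing an aromatic amide substituent with an acid-bearing chain

A few compounds are considered here, and "the series" means these few. Any claim that something is new, unique, unknown or untested is made for them only; others in the source may bear on it.

Measured compounds:
compound 1 `CCCCCCCCCCCC(=O)OC[C@H](CSC[C@@H](N)C(=O)NC(C)c1ccccc1)OC(=O)CCCCCCCCCCC` gives 9900 nM
compound 2 `CCCCCCCCCCCC(=O)OC[C@H](CSC[C@@H](N)C(=O)NC(C)c1ccc(O)cc1)OC(=O)CCCCCCCCCCC` gives 2890 nM

In an assay on HEK293 cells for agonist activity at Toll-like receptor 2 (Homo sapiens) (a lower number here means that less compound is needed, a higher number that more compound is needed for the effect), compound 2 stands lowest of the two numbers measured; the nearest is compound 1, and the step of a 3.4-fold lower number from compound 1 to compound 2 (0.53 log units; beyond the scatter) lies beyond the usual scatter. The next compound, compound 3 `CCCCCCCCCCCC(=O)OC[C@H](CSC[C@@H](N)C(=O)N[C@@H](CC)COCC(=O)O)OC(=O)CCCCCCCCCCC`, changes the same end of the molecule again: 1-((carboxymethoxy)methyl)propyl in place of 1-(4-hydroxyphenyl)ethyl on an amide-type nitrogen. The earlier step added a hydroxy group to a ring that stays in place; here the whole ring leaves and an acyclic group with a carboxylic acid enters, so that step does not bear directly on this one. Among the compounds with values here, no measured compound shows what removing the ring does. The outcome is therefore uncertain, and the expected step of a 1.7-fold higher number from compound 2 to compound 3 (0.24 log units; within the scatter) is set close to no change, with a wide range. Compound 3 is estimated at 5000 nM, expected between 1000 nM and 25000 nM.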

Compound 3, half-maximal effective concentration: 6500 nM
Estimate against measurement, compound 3: 1.3-fold (0.11 log units) below; the range from low to high includes it.
By their numbers in this assay, from the lowest: compound 2; then compounds 3 and 1 (each within the scatter of the next).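

In this assay the aromatic ring on the amide-type nitrogen proves not to be essential for activity: the ring-free 1-((carboxymethoxy)methyl)propyl group gives only a 2.2-fold higher number from compound 2 to compound 3 (0.35 log units; beyond the scatter) and so keeps a response in the same general range. Compared with the plain 1-phenylethyl group, the same chain gives a 1.5-fold lower number from compound 1 to compound 3 (0.18 log units; within the scatter) and the two cannot be told apart, so the ring and the chain with its carboxylic acid serve about equally here, while only the hydroxy-bearing ring of compound 2 stands clearly apart. Nothing available explains these numbers.

From the compounds shown here alone, what the carboxylic acid contributes on its own, separately from the ring-free chain that carries it, remains open. A matching chain ending in a methyl ester or a primary alcohol would separate the two.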